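The compounds below may be only part of what the source reports. "The series", "measured", "known", "first", "only" and "open" are said of these compounds alone.

Of the compounds shown here, three built on a shared core have been tested in a functional assay on FaDu cells (Homo sapiens) for cytotoxicity, read by MTT assay, with a stated time of 72 h; on this read-out higher numbers stand for lower toxicity in this test and lower numbers for higher toxicity in this test. Compound 1 `CCn1cc(C(=O)C(=O)Nc2ccncc2)c2ccccc21` gives > 10000 nM, which is a limit of the assay. Compound 3 `COc1ccc(NC(=O)C(=O)c2cn(C(C)C)c3ccc(Cl)cc23)cc1` gives > 10000 nM, which is also a limit of the assay. Among the compounds with values here, compound 2 `COc1ccc(NC(=O)C(=O)c2cn(C(C)C)c3ccccc23)nn1` gives 2270 nM, the only actual number in the set, which makes it the single fixed point for comparison. Within the data shown here, no two tested compounds differ in just one place, so no measured step can guide a prediction.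

Compound 4 `CC(C)n1cc(C(=O)C(=O)Nc2cccnc2)c2ccccc21` has not yet been measured and differs from compound 2 in one place: pyridin-3-yl in place of 6-methoxypyridazin-3-yl on an amide-type nitrogen. The swap happens on an amide-type nitrogen, and the rest of the molecule stays the same. With so little data, any forecast is rough. The expected direction is toward higher numbers, meaning lower toxicity, since the tested set shows (the limit of > 10000 nM in this assay, at which 2 of the 3 values shown sit). The estimated size of a 2.6-fold higher number from compound 2 to compound 4 (0.42 log units; beyond the scatter) is modest, only a little beyond the usual scatter of this assay. A result reported only as a limit would also be no surprise. For compound 4 the expected value is 6000 nM, with an estimated range from 2000 nM to 10000 nM.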

Compound 4, concentration lethal to 50% of the cells: > 10000 nM
Compound 4: a limit, no number; the forecaster's own chance of this, stated with the estimate: 50%; middle value at least 1.6-fold (0.22 log units) away from the limit.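

In this assay, within the data shown here, swapping 6-methoxypyridazin-3-yl for pyridin-3-yl on the amide-type nitrogen gives an at least 4.4-fold higher number from compound 2 to compound 4 (0.64 log units; beyond the scatter), the first measured step at this place, and it is larger than the usual scatter of the test. Compound 4 gives > 10000 nM, which is a limit of the assay and not a number. The step therefore has a floor but no known top, and compound 2 remains the only compound in the set with an actual number, while the others all sit at the same limit: the limit of > 10000 nM in this assay, at which 3 of the 4 values shown sit.

The swap changes two things at once, since the ring loses one of its nitrogen atoms and the methoxy group disappears, and the compounds shown cannot say which of these two differences accounts for the step. A plain pyridazin-3-yl group on the same amide-type nitrogen would begin to separate the two, as would a pyridazin-3-yl group carrying an amine in place of the methoxy group, and either could show whether a measurable number in this test depends on the ring, on the methoxy group, or on both.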